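The source may hold more compounds than are shown below. What is called first, only, known or untested is meant among the compounds shown, and "the series" means these compounds.

Compound 1 `Cc1ccccc1N(C)C(=O)c1ccc(-c2ccc(OS(N)(=O)=O)cc2)o1` has been measured in an assay on T47D cells for inhibition of Steryl-sulfatase (Homo sapiens), read by HPLC, with a stated time of 24 h (on this read-out higher numbers stand for weaker inhibition and lower numbers for stronger inhibition), where compound 1 gives 31 nM. Among the two numbers recorded so far this is the higher one; its only neighbour is compound 2 `Cc1ccccc1N(C)C(=O)c1ccc(-c2ccc(OS(N)(=O)=O)c(F)c2)o1`, which in this assay gives 17 nM. The step of a 1.8-fold lower number from compound 1 to compound 2 (0.26 log units; within the scatter) comes with a fluoro in place of hydrogen on an aromatic carbon. It stays within the scatter, and the two compounds are treated as alike in this read-out.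

Compound 3 `Cc1ccccc1N(C)C(=O)c1ccc(-c2ccc(OS(N)(=O)=O)cc2Cl)o1` has not yet been measured in this assay. It differs from compound 1 by chloro in place of hydrogen on an aromatic carbon. Going by the values given here, the one measured step that bears on this change, a 1.8-fold lower number from compound 1 to compound 2 (0.26 log units; within the scatter), also swaps a hydrogen for a halogen on the same six-membered ring, though with a different halogen and at a different place on that ring, and it did not move beyond the scatter. On that basis no step beyond the scatter is expected from compound 1 to compound 3, a 1.0-fold lower number from compound 1 to compound 3 (0.01 log units; within the scatter). For compound 3 the expected value in this assay is 30 nM, with a range from 10 nM to 90 nM.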

Compound 3, half-maximal inhibitory concentration: 29 nM
Compound 3: the middle estimate sits 1.0-fold (0.01 log units) above what was measured; low and high end bracket the measured number.
By their numbers in this assay, from the lowest: compounds 2, 3 and 1 (each within the scatter of the next).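

Setting a chloro on an aromatic carbon ortho to a large group and meta to the sulfamoyloxy group gives in this assay a 1.1-fold lower number from compound 1 to compound 3 (0.03 log units; within the scatter) and so adds a second place on the six-membered ring where a single halogen atom brings no step beyond the scatter. The earlier pair showed this only for fluoro at one other place, so the result now extends to a larger halogen at a new position, though it remains a single example for this position. No measurement shown gives a reason for the number staying within the scatter at this position.

Chloro and fluoro cannot be ranked against each other here, since they sit at different places and a fair comparison would need both halogens at the same place on the ring. From the compounds shown here alone, it also remains open whether this position would stay within the scatter with a group of another kind, such as an amine, a carboxylic acid or a longer chain, which would put more than one heavy atom there.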